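From methoxymethyl to hydroxymethyl in compound 3

A few compounds are considered here, and "the series" means these few. Any claim that something is new, unique, unknown or untested is made for them only; others in the source may bear on it.

Compound 1 `COC[C@H]1C[C@@](CC(C)C)(C(=O)O)N(C(=O)c2ccc(C(C)(C)C)c(OC)c2)[C@H]1c1nccs1` gives 59%
Compound 2 `COC[C@@H]1C[C@@](CC(C)C)(C(=O)O)N(C(=O)c2ccc(C(C)(C)C)c(OC)c2)[C@H]1c1nccs1` gives 44%

In an in vivo ADME assay on the whole organism (strain Sprague-Dawley) for pharmacokinetics, with Rattus norvegicus as the target (a lower number here means that a smaller share of the oral dose reaches the circulation, a higher number that a larger share of the oral dose reaches the circulation), compound 2 is the lower of the two measured compounds. For the measured compounds named here, the one measured step is a number 15 percentage points lower from compound 1 to compound 2 (beyond the scatter) and it comes with the fact that compounds 1 and 2 differ only in the configuration as drawn (so no group is exchanged in it). Compound 3 `COc1cc(C(=O)N2[C@@H](c3nccs3)[C@H](CO)C[C@@]2(CC(C)C)C(=O)O)ccc1C(C)(C)C` differs from compound 2 by hydrogen in place of methyl on an oxygen on a saturated carbon (hydrogen in place of methyl on an oxygen on a saturated carbon, or methoxymethyl to hydroxymethyl). Going by the values given here, no measured step covers such a change. Among the compounds with values here, the only guide to size is therefore a number 15 percentage points lower from compound 1 to compound 2 (beyond the scatter) and it is a rough one. A modest fall is expected, with wide uncertainty. The estimated move is a number 12 percentage points lower from compound 2 to compound 3 (beyond the scatter) as an expected step of that modest size. The expected value for compound 3 is 32% (estimated range 12% to 52%)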

Compound 3, oral bioavailability: 11%
Compound 3: middle estimate off by 21 percentage points, on the high side, outside the stated range (below it).
By their numbers in this assay, from the lowest: compound 3; then compound 2; then compound 1.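

In this assay, for the compounds shown here, hydrogen in place of methyl on an oxygen on a saturated carbon gives a number 33 percentage points lower from compound 2 to compound 3 (beyond the scatter), a large step and the first measured exchange of a group at this position. Going by these compounds alone, the only earlier step, a number 15 percentage points lower from compound 1 to compound 2 (beyond the scatter), is modest and concerns configuration alone, whereas this one shows that the methyl of the methoxymethyl group itself weighs more heavily on the read-out than that change of configuration did. Nothing given here explains why removing this methyl has so large an effect.

On these data alone, whether the same change from methoxymethyl to hydroxymethyl would have a similar size in the configuration of compound 1 stays open. So does the outcome with a longer chain on this oxygen, as in ethoxymethyl, or with an amine in place of the hydroxy group.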